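Swapping one substituted phenyl group on a weak compound

The source may hold more compounds than are shown below. What is called first, only, known or untested is meant among the compounds shown, and "the series" means these compounds.

Values measured in a functional assay on MCF cells (Homo sapiens) for antiproliferative activity, with a stated time of 72 h; a lower number here means a stronger inhibitor, a higher number a weaker inhibitor
Compound 1 `OC[C@H]1O[C@@H](n2cnc3c(NCc4ccc(Cl)c(Cl)c4)ncnc32)[C@H](O)[C@@H]1O` gives 88800 nM
Compound 2 `OC[C@H]1O[C@@H](n2cnc3c(NCc4ccccc4OC(F)F)ncnc32)[C@H](O)[C@@H]1O` gives > 166000 nM (a limit, not a number)

For compound 2, this assay reports only > 166000 nM, which is a limit and not a number. The data therefore show (the limit of > 166000 nM in this assay, at which 1 of the 2 values shown sits). Among the measured compounds shown here, compound 3 `OC[C@H]1O[C@@H](n2cnc3c(NCc4cccc(C(F)(F)F)c4)ncnc32)[C@H](O)[C@@H]1O` keeps the shared core and changes only one group: 3-(trifluoromethyl)phenyl takes the place of 2-(difluoromethoxy)phenyl, (3-(trifluoromethyl)phenyl in place of 2-(difluoromethoxy)phenyl on a saturated chain carbon bound to a nitrogen on an aromatic ring).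

For the measured compounds named here, one measured step bears on this change, since it also exchanges the substituted phenyl group at the same place. That step is an at least 1.8-fold higher number from compound 1 to compound 2 (0.27 log units; that floor lies within the scatter). Going by these compounds, it is small, and its true size is unknown. Going by the values given here, with compound 1 at 88800 nM as the only actual number, compound 3 is expected to stay in the same high range. No step beyond the usual scatter is expected in this assay, with at most a slight lean towards a lower number. The expected change is an at least 1.2-fold lower number from compound 2 to compound 3 (0.10 log units; that floor lies within the scatter). For compound 3, the estimated value is 130000 nM, with an expected range of 60000 nM to 280000 nM.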

Compound 3, half-maximal inhibitory concentration: > 166000 nM
Compound 3 gave a limit, no number (the forecaster's own chance of this, stated with the estimate: 45%); at least 1.2-fold (0.10 log units) between middle value and limit.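

In this assay compound 3 gives > 166000 nM, which is a limit and not a number. Compound 3 therefore shows that this outcome is not confined to 2-(difluoromethoxy)phenyl, since 3-(trifluoromethyl)phenyl, which has no oxygen and no hydrogen-bond acceptor, also yields no actual number when placed on the saturated chain carbon bound to a nitrogen on an aromatic ring. Going by these compounds, exchanging 3,4-dichlorophenyl for 3-(trifluoromethyl)phenyl gives an at least 1.8-fold higher number from compound 1 to compound 3 (0.27 log units; that floor lies within the scatter), so this change, like the earlier one, shows no difference beyond the scatter, although its true size is unknown.

The step from compound 2 to compound 3 cannot be read, because both compounds end at the same limit: the limit of > 166000 nM in this assay, at which 2 of the 3 values shown sit.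

On these data alone, the true values of compound 2 and compound 3 therefore stay unknown, and the three compounds cannot be put in order. Also open, as far as these compounds go, is whether a different kind of group on the same saturated chain carbon, such as an amine, a carboxylic acid or a longer chain, would give a clearly lower number in this assay.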